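A few compounds are considered here, and "the series" means these few. Any claim that something is new, unique, unknown or untested is made for them only; others in the source may bear on it.

Of the compounds shown here, two that share one core have been tested in an ADME assay on HaCaT cells (Homo sapiens) for cytotoxicity, read by MTT assay, with a stated time of 48 h; on this read-out higher numbers stand for weaker inhibition and lower numbers for stronger inhibition. Compound 1 `Fc1ccc2[nH]c(-c3cn(-c4ccccc4)nc3-c3ccc(Cl)cc3)nc2c1`, which carries fluoro, gives > 50000 nM, and this is a limit of the assay and not a number. Compound 2 `Clc1ccc(-c2nn(-c3ccccc3)cc2-c2nc3cc(Br)ccc3[nH]2)cc1`, which carries bromo at the same place, gives > 50000 nM, which is again a limit and not a number. Compound 2 therefore stands with compound 1 at the limit of > 50000 nM in this assay, at which 2 of the 2 values shown sit.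

The next compound, compound 3 `COc1ccc2[nH]c(-c3cn(-c4ccccc4)nc3-c3ccc(Cl)cc3)nc2c1`, keeps the shared core and changes one group, with methoxy in place of bromo on an aromatic carbon. Among the compounds with values here, the only measured step is a step that the two limits leave unreadable from compound 1 to compound 2, so it offers no size to carry forward. With so little to go on, the safest expectation is no step beyond the scatter in this assay, in either direction. That expectation rests on compound 2 and its limit of > 50000 nM. The expected change is a number no higher from compound 2 to compound 3 (the limit leaves the size open). For compound 3 the estimated value is 50000 nM, with an expected range from 20000 nM to 100000 nM.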

Compound 3, half-maximal inhibitory concentration: > 50000 nM
Compound 3 was reported as a limit; the forecaster's own chance of this, stated with the estimate: 70%; the middle value lies on the limit itself.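

In this assay, the result for compound 3 is a limit and not a number, so no step can be read from compound 1 or compound 2 to compound 3. All three compounds sit together: the limit of > 50000 nM in this assay, at which 3 of the 3 values shown sit.

The compounds shown leave open whether fluoro, bromo and methoxy at this place differ at all in this assay, and at what concentration any of the three would reach half-maximal inhibition.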